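Working notes: diethylamino in place of piperidin-1-yl

This account rests on a few compounds, and the source may have more. Where it says the series, first, only, none or still open, it means among the compounds named here.

Measured so far in an ADME assay for permeability, using PAMPA (on this read-out lower numbers stand for lower permeability and higher numbers for higher permeability), for this series:

- compound 1 `NC(=O)c1cc(-c2ccccc2)cc2c(C3CCN(S(=O)(=O)CCCN4CCCCCC4)CC3)c[nH]c12` gives 290 nm/s 
- compound 2 `NC(=O)c1cc(-c2ccccc2)cc2c(C3CCN(S(=O)(=O)CCCN4CCCCC4)CC3)c[nH]c12` gives 240 nm/s 

Going by the values given here, compound 2 stands within the scatter of compound 1, the only other measured compound, so neither can be ranked above the other. The step to compound 3 `CCN(CC)CCCS(=O)(=O)N1CCC(c2c[nH]c3c(C(N)=O)cc(-c4ccccc4)cc23)CC1` puts diethylamino in place of piperidin-1-yl on a saturated chain carbon, three bonds along the chain from a sulfonyl sulfur. Among the compounds with values here, one measured step bears on this place: a 1.2-fold lower number from compound 1 to compound 2 (0.08 log units; within the scatter) for piperidin-1-yl in place of azepan-1-yl. Within the data shown here, that step stays within the scatter, but it only exchanges one ring for another, and no measured step shows a group without a ring here. With compound 2 at 240 nm/s as the starting point and that single small step as the guide, no change beyond the scatter is expected in this assay and no direction is favoured. The expected step is no change at the digits printed from compound 2 to compound 3 (within the scatter) on this evidence. Compound 3 is estimated at 240 nm/s with a range of 130 nm/s to 440 nm/s expected.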

Compound 3, apparent permeability: 200 nm/s
Compound 3: the middle estimate sits 1.2-fold (0.08 log units) above what was measured; the range from low to high includes it.
By their numbers in this assay, from the lowest: compounds 3, 2 and 1 (each within the scatter of the next).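

In this assay, going by these compounds alone, the place on a saturated chain carbon, three bonds along the chain from a sulfonyl sulfur, now carries for the first time a group with no ring: diethylamino in place of piperidin-1-yl reads as a 1.2-fold lower number from compound 2 to compound 3 (0.08 log units; within the scatter) and diethylamino in place of azepan-1-yl reads as a 1.5-fold lower number from compound 1 to compound 3 (0.16 log units; within the scatter) in the same series. All three compounds therefore sit within the scatter of one another, so neither the ring of compound 1 and compound 2 nor the difference in ring size separates them on this read-out, and no order can be drawn among the three groups. Nothing measured alongside these numbers offers any account of them.

On these data alone, whether this tolerance extends to groups with a further hetero atom or a charge stays open, for instance morpholin-4-yl, a primary amine or a carboxylic acid at the end of the chain. Also open, as far as these compounds go, is how the read-out responds to the chain itself, such as a longer chain between the sulfonyl sulfur and the diethylamino group.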